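Allyl-substituted diketopiperazine-like series: arylidene swap, cytotoxicity

The source may hold more compounds than are shown below. What is called first, only, known or untested is meant among the compounds shown, and "the series" means these compounds.

Compound 1 `C=CCn1c(=O)/c(=C\c2cccc(F)c2)[nH]c(=O)/c1=C\c1ccccc1OC`: 25600 nM
Compound 2 `C=CCn1c(=O)/c(=C\c2ccc(F)c(Br)c2)[nH]c(=O)/c1=C\c1ccccc1OC`: "not active" (no number reported)
Compound 3 `C=CCn1c(=O)/c(=C\c2ccc(C)cc2)[nH]c(=O)/c1=C\c1ccccc1OC`: to be measured

In a functional assay on NCI-H1975 cells (Homo sapiens) for cytotoxicity, read by CCK-8 assay, with a stated time of 72 h (a lower number here means a stronger inhibitor, a higher number a weaker inhibitor), compound 1 gives 25600 nM. For the measured compounds named here, for compound 2 the same read-out is reported only as "not active" (no number reported), so no number stands beside it and no step between the two measured compounds can be sized. Compound 2 is thus placed only in words: it produced no measurable inhibition under the conditions used.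

Compound 3 differs from compound 2 in one place: 4-methylphenyl in place of 3-bromo-4-fluorophenyl on a double-bonded chain carbon bound to an aromatic carbon. Both measured compounds carry a halogenated ring at this position and neither shows appreciable inhibition, so the exchange for 4-methylphenyl is not expected to move the series into a clearly more potent range; a result at or near the weak end, or another report without a number, seems the most likely outcome. For compound 3 the read-out in this assay is estimated at 30000 nM, with a plausible range from 10000 nM to 100000 nM, the measurement itself still outstanding.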

Compound 3, half-maximal inhibitory concentration: "not active" (no number reported)
No number was reported for compound 3, and the estimate cannot be compared.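

With compound 2 at "not active" (no number reported) and compound 3 at "not active" (no number reported) in this assay, neither carries a number, so no step can be read between them. The compounds shown leave open whether exchanging 3-bromo-4-fluorophenyl for 4-methylphenyl changes inhibition at all. No supporting evidence bears on this result.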